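Bromo to sec-butyl on the shared core of compound 1

The source may hold more compounds than are shown below. What is called first, only, known or untested is meant among the compounds shown, and "the series" means these compounds.

Compound 1 `Cc1cc(Br)c(S(C)(=O)=O)cc1C(=O)N=C(N)N` gives the lower of the two measured values in a functional assay for inhibition of sodium/hydrogen exchanger (Oryctolagus cuniculus) (on this read-out higher numbers stand for weaker inhibition and lower numbers for stronger inhibition), 12 nM; compound 2 `CCc1cc(Br)c(S(C)(=O)=O)cc1C(=O)N=C(N)N` sits higher with 41 nM. Within the data shown here, the one measured step, a 3.4-fold higher number from compound 1 to compound 2 (0.53 log units; beyond the scatter), comes from methyl in place of hydrogen on a saturated chain carbon bound to an aromatic carbon and amounts to a modest weakening. Compound 3 `CCC(C)c1cc(C)c(C(=O)N=C(N)N)cc1S(C)(=O)=O` differs from compound 1 by sec-butyl in place of bromo on an aromatic carbon. Among the measured compounds shown here, no measured step covers this change, which sits on another aromatic carbon and exchanges a halogen for a four-carbon chain; the step from compound 1 to compound 2 is only an indirect guide. A weakening of compound 3 relative to compound 1 is therefore expected, a 3.8-fold higher number from compound 1 to compound 3 (0.57 log units; beyond the scatter), in this assay, with wide uncertainty. The estimate for compound 3 in this assay is 45 nM, expected to fall between 10 nM and 250 nM.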

Compound 3, half-maximal inhibitory concentration: 8 nM
Compound 3: middle estimate off by 5.6-fold (0.75 log units), on the high side, outside the stated range (below it).
By their numbers in this assay, from the lowest: compounds 3 and 1 (each within the scatter of the next); then compound 2.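

On the aromatic carbon ortho to a methylsulfonyl group, the exchange of bromo for sec-butyl gives a 1.5-fold lower number from compound 1 to compound 3 (0.18 log units; within the scatter) in this assay, so four carbons can enter where one bromine leaves with no difference beyond the scatter. The step at the other aromatic position, a 3.4-fold higher number from compound 1 to compound 2 (0.53 log units; beyond the scatter), is beyond the scatter, so the size of that step does not carry over to this position. Nothing measured here bears on why the numbers of this pair stay so close.

The compounds shown hold only bromo and sec-butyl at this position, so it remains open whether a longer chain, an amine or a carboxylic acid would stay in the same range in this assay. Also open, from the compounds shown here alone, is whether sec-butyl gives a similar result with an ethyl group in place of the methyl group.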